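The compounds below may be only part of what the source reports. "The series", "measured", "known", "first", "only" and "open" are said of these compounds alone.

Two compounds from this series have so far been run through an ADME assay on Huh-7 cells (Homo sapiens) for cytotoxicity; a higher number here means that more compound is tolerated, a lower number that less compound is tolerated. Compound 1 `Cc1ccccc1-c1nn(-c2ccc(F)cc2F)cc1CNCCCCO` carries a 2-methylphenyl on the shared core; in this assay compound 1 gives > 20000 nM, which is a limit of the assay and not a number. Compound 2 `CN1CCN(CCNCc2cn(-c3ccc(F)cc3F)nc2-c2cccc(Cl)c2)CC1` carries a 3-chlorophenyl in the same position and a different chain; in this assay compound 2 gives 15000 nM. Going by the values given here, compound 2 therefore holds the only numerical value shown, while the other value shown is a limit (the limit of > 20000 nM in this assay, at which 1 of the 2 values shown sits). Compound 3 `Cc1ccccc1-c1nn(-c2ccc(F)cc2F)cc1CNCCN1CCN(C)CC1` keeps the chain of compound 2 and differs from it in one place: 2-methylphenyl in place of 3-chlorophenyl on an aromatic carbon. Among the compounds with values here, no measured pair separated by exactly this change exists, so the size of the step has to be estimated. A small move toward higher tolerated concentration seems plausible, because the limit of > 20000 nM in this assay, at which 1 of the 2 values shown sits, is where compound 1, the other 2-methylphenyl bearer, sits. Compound 3 is thus expected to give about 18000 nM, with a range from 9000 nM to 40000 nM. The step from compound 2 to compound 3 is estimated at a 1.2-fold higher number from compound 2 to compound 3 (0.08 log units; within the scatter), within the scatter, with a fair chance that only a limit is reported.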

Compound 3, half-maximal cytotoxic concentration: > 20000 nM
Compound 3 ended at the assay's limit (the forecaster's own chance of this, stated with the estimate: 45%); at least 1.1-fold (0.04 log units) between middle value and limit.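

In this assay, going by these compounds alone, 2-methylphenyl in place of 3-chlorophenyl on this aromatic carbon gives the first step that can be read at all: an at least 1.3-fold higher number from compound 2 to compound 3 (0.12 log units; that floor lies within the scatter). Compound 3 gives > 20000 nM, which is a limit of the assay and not a number, and the step is therefore only a floor that does not show a change beyond the scatter. The step between compound 1 and compound 3, which carry the same 2-methylphenyl and differ in the chain, cannot be read, and the series now rests mostly on limits: the limit of > 20000 nM in this assay, at which 2 of the 3 values shown sit.

The compounds shown leave open whether the chlorine or its place on the phenyl ring matters here, a question that a 2-chlorophenyl or a 3-methylphenyl on this same carbon would address. They also leave open how the 4-methylpiperazin-1-yl chain of compound 3 compares with the chain of compound 1, and how a carboxylic acid or a longer chain in that position would read in this assay.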